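Thiophen-3-yl replacing 4-chlorophenyl on the shared core

The compounds below may be only part of what the source reports. "The series", "measured", "known", "first", "only" and "open" are said of these compounds alone.

Within the data shown here, in a functional assay on HeLa cells (Homo sapiens) for inhibition, read by MTT assay, with a stated time of 48 h (a higher number here means a weaker inhibitor, a lower number a stronger inhibitor), compound 1 `c1ccc(Sc2c(-c3cccs3)nc3ccccn23)cc1` gives 19900 nM and compound 2 `Clc1ccc(-c2nc3ccccn3c2Sc2ccccc2)cc1` gives 62000 nM as the higher of the only two numbers so far, which makes compound 2 the weaker inhibitor of the pair. Compound 3 `c1ccc(Sc2c(-c3ccsc3)nc3ccccn23)cc1` departs from compound 2 in one place, with thiophen-3-yl in place of 4-chlorophenyl on an aromatic carbon. The counted difference is thiophen-3-yl in place of 4-chlorophenyl on an aromatic carbon and it sits next to the ring atom that bears a phenylsulfanyl group.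

Among the measured compounds shown here, only one measured step bears on this change. It is a 3.1-fold higher number from compound 1 to compound 2 (0.49 log units; beyond the scatter) and it came with 4-chlorophenyl taking the place of thiophen-2-yl at the same carbon, a modest step but beyond the scatter. Read in reverse, that step suggests that a thiophene ring here should bring the number down, so a modest drop of similar size is expected in this assay for this change, although thiophen-3-yl itself remains untested. The estimated step is a 2.5-fold lower number from compound 2 to compound 3 (0.39 log units; beyond the scatter) towards a stronger inhibitor. For compound 3 the estimate is 25000 nM with an expected range of 10000 nM to 60000 nM as its likely span.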

Compound 3, half-maximal inhibitory concentration: 76000 nM
Estimate against measurement, compound 3: 3.0-fold (0.48 log units) below; measured number above the stated range.
By their numbers in this assay, from the lowest: compound 1; then compounds 2 and 3 (each within the scatter of the next).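

In this assay the step of a 1.2-fold higher number from compound 2 to compound 3 (0.09 log units; within the scatter) shows that at this carbon, which bears the aryl ring on the shared core, thiophen-3-yl and 4-chlorophenyl cannot be told apart, even though they differ in ring size and in the hetero atom they carry. The step of a 3.8-fold higher number from compound 1 to compound 3 (0.58 log units; beyond the scatter), taken with a 3.1-fold higher number from compound 1 to compound 2 (0.49 log units; beyond the scatter), shows that the thiophene ring as such does not set compound 1 apart, since the advantage holds only for thiophen-2-yl and does not carry over to the isomer joined through its other ring carbon, leaving compound 1 as the strongest inhibitor of the three. Nothing measured here accounts for this difference between the two thiophene attachments.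

The compounds shown leave open whether an amine such as a piperidine or a carboxylic acid on this carbon would match thiophen-2-yl or fall level with the other two rings. They also leave open what the phenylsulfanyl group, shared by all three compounds, contributes, and whether a longer chain or a methoxy group on its phenyl ring would shift the numbers in this assay at all.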